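Aryl for Alkyl at the Sulfur-Bound Carbon

The source may hold more compounds than are shown below. What is called first, only, known or untested is meant among the compounds shown, and "the series" means these compounds.

Of the compounds shown here, three sharing one core have been measured in an assay on HEK293 cells for displacement of a labelled ligand from prostaglandin D2 receptor 2 (Homo sapiens); on this read-out lower numbers stand for stronger inhibition and higher numbers for weaker inhibition. Compound 1 `O=C(O)Cn1c(SCCCCOc2ccccc2)nc2ccccc21` gives 1400 nM. Compound 2 `CCCCCCSc1nc2ccccc2n1CC(=O)O` gives 1360 nM, and compound 3 `CCOC(=O)CCCCSc1nc2ccccc2n1CC(=O)O` gives 2360 nM. Compound 2 sits at the low end of the three numbers, yet only within the scatter: the step of a 1.0-fold lower number from compound 1 to compound 2 (0.01 log units; within the scatter) is within the scatter, as are a 1.7-fold higher number from compound 2 to compound 3 (0.24 log units; within the scatter) and a 1.7-fold higher number from compound 1 to compound 3 (0.23 log units; within the scatter), so the three numbers are not distinguishable.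

Compound 4 `O=C(O)Cn1c(SCc2cccc(Cl)c2)nc2ccccc21` is not yet measured. From compound 2 it differs in one place: 3-chlorophenyl in place of pentyl on a saturated chain carbon bound to a sulfur. The three measured steps all concern the saturated chain carbon four bonds along the chain from a sulfur, where phenoxy, ethyl and ethoxycarbonyl gave numbers within the scatter of one another. For the measured compounds named here, no measured step touches the chain carbon bound to the sulfur, and no measured compound carries an aromatic ring there, so none bears on this change directly. The set does show that compound 1, with phenoxy on the chain, gave 1400 nM without a shift beyond the scatter. Compound 4 is therefore expected to show no step beyond the scatter in this assay, the expected step being a 1.1-fold lower number from compound 2 to compound 4 (0.05 log units; within the scatter). The estimate for compound 4 is 1200 nM, ranging from 350 nM to 4000 nM, the width reflecting an untested change.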

Compound 4, half-maximal inhibitory concentration: 186 nM
Compound 4: the middle estimate sits 6.5-fold (0.81 log units) above what was measured; measured number outside the range, below it.
By their numbers in this assay, from the lowest: compound 4; then compounds 2, 1 and 3 (each within the scatter of the next).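

In this assay, for the compounds shown here, the step of a 7.3-fold lower number from compound 2 to compound 4 (0.86 log units; beyond the scatter) is the first in the set to lie beyond the scatter, and it falls on the saturated chain carbon bound to a sulfur, a place that no earlier pair of compounds varied. The earlier changes all sat on the chain carbon four bonds along from a sulfur and left the numbers indistinguishable, so those compounds gave no sign that a single replacement on this chain could move the number by more than the scatter. No measurement shown here accounts for this step, which remains an observation about 3-chlorophenyl in place of pentyl and nothing more.

The ring and the chlorine enter together in this one change, so the compounds shown cannot separate their shares, and a plain phenyl on the same carbon would be the direct comparison. From the compounds shown here alone, whether the lower number survives with fluorine or a methoxy group in place of the chlorine, or with a pyridine ring in place of the benzene ring, also stays open.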